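The source may report more compounds than this note shows. Statements on the series, on what has been measured and on what is new or still open speak of the compounds shown alone.

Compound 1, `COc1cc(Cl)cc(-c2nn(-c3cccc(NC(=O)Nc4ccc(Cl)c(C(F)(F)F)c4)c3)cc2-c2ccncc2)c1`, in a functional assay on NCI-H522 cells (Homo sapiens) for inhibition, read by sulforhodamine B assay, with a stated time of 48 h, tested at 0.01 uM (a higher number here means a weaker effect of the compound at the concentration tested, a lower number a stronger effect), gives 93%.
Compound 2, `COc1cc(Cl)cc(-c2nn(-c3cccc(NC(=O)Nc4ccc(Cl)c(Cl)c4)c3)cc2-c2ccncc2)c1`, in this assay gives 95%.
Compound 3, `COc1cc(Cl)cc(-c2nn(-c3cccc(NC(=O)Nc4cccc(C(F)(F)F)c4)c3)cc2-c2ccncc2)c1`, in this assay gives 95%.

All three numbers lie within the usual scatter of each other, so none of the compounds can be set apart. Compound 3 sits level with compound 2, as no change at the digits printed from compound 2 to compound 3 (within the scatter) shows, and differs from compound 1 only by a number 2 percentage points higher from compound 1 to compound 3 (within the scatter). Every change tried so far, including a number 2 percentage points higher from compound 1 to compound 2 (within the scatter), has left the read-out essentially where it was.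

Compound 4, `COc1cc(Cl)cc(-c2nn(-c3cccc(NC(=O)c4cccc(C(F)(F)F)c4)c3)cc2-c2ccncc2)c1`, is not yet measured. It differs from compound 3 at the carbonyl carbon: 3-(trifluoromethyl)phenyl in place of (3-(trifluoromethyl)phenyl)amino on a carbonyl carbon. For the measured compounds named here, none of the measured steps touches this part of the molecule; each of them altered a group on the outer aromatic ring, and each stayed within the scatter. Going by the values given here, there is thus no measured step that speaks directly to this change, only the observation that the shared core has so far given the same weak effect whatever was attached. The step from compound 3 to compound 4 is therefore expected to be a number 2 percentage points lower from compound 3 to compound 4 (within the scatter). In this assay compound 4 is estimated to give 93%, with a likely range from 82% to 103%.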

Compound 4, a percentage reported as activity, at one concentration (the size of the read-out at that concentration, not a potency): 51%
The estimate for compound 4 lay 42 percentage points above the measured number; the measured number lies below the stated range.
By their numbers in this assay, from the lowest: compound 4; then compounds 1, 2 and 3 (each within the scatter of the next).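

Until now only the outer aromatic ring had changed; here the link itself changes, as (3-(trifluoromethyl)phenyl)amino on the carbonyl carbon gives way to 3-(trifluoromethyl)phenyl, removing one nitrogen and its hydrogen-bond donor, and in this assay this gives a number 44 percentage points lower from compound 3 to compound 4 (beyond the scatter), a much stronger effect at the concentration tested. The comparisons with the other two outer rings point the same way, with a number 44 percentage points lower from compound 2 to compound 4 (beyond the scatter) and a number 42 percentage points lower from compound 1 to compound 4 (beyond the scatter), so among these four compounds the read-out responds at this carbonyl position, while the outer-ring changes stayed within the scatter. No measurement here explains why this change has such a large effect.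

Only one outer ring is shown on the new amide link, so whether 3,4-dichlorophenyl or 4-chloro-3-(trifluoromethyl)phenyl would behave the same there remains open. Also open, on these data alone, is what a methylene group or a longer carbon chain would do in place of the amino nitrogen.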